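A Phenylethenyl Group in Place of Methylphenyl

The source may report more compounds than this note shows. Statements on the series, on what has been measured and on what is new or still open speak of the compounds shown alone.

Compound 1, `COc1ccc(C(O)(Cc2ccc(C)cc2)c2cccc3ccccc23)c(OC)c1OC`: 18700 nM in a functional assay on A549 cells (Homo sapiens) for inhibition, read by sulforhodamine B assay, with a stated time of 48 h; a lower number here means a stronger inhibitor, a higher number a weaker inhibitor
Compound 2, `COc1ccc(C(c2ccccc2O)c2cccc3ccccc23)c(OC)c1OC`: 13600 nM in this assay

Compound 1 gives the higher of the two numbers seen so far, but its gap to compound 2 lies within the usual scatter of this assay, so the two cannot be told apart; both sit in the weak range. Compound 3, `COc1ccc(C(O)(C/C=C\c2ccccc2)c2cccc3ccccc23)c(OC)c1OC`, keeps the core of compound 1 and differs from it in one place: 2-phenylethenyl in place of 4-methylphenyl on a saturated chain carbon, two bonds along the chain from two aromatic carbons and an oxygen on a saturated carbon. Among the measured compounds shown here, no measured pair shows what such a swap does in this assay, so the expectation rests only on compound 1 itself. Because compound 1 gives 18700 nM and the change keeps one aromatic ring and adds little else, the step of a 1.2-fold lower number from compound 1 to compound 3 (0.07 log units; within the scatter) is expected to be small, with no clear direction beyond the scatter. Compound 3 is therefore estimated at 16000 nM, with a likely range from 5000 nM to 50000 nM.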

Compound 3, half-maximal inhibitory concentration: 17600 nM
Compound 3: middle estimate off by 1.1-fold (0.04 log units), on the low side, within the range that was stated.
By their numbers in this assay, from the lowest: compounds 2, 3 and 1 (each within the scatter of the next).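

Among the compounds shown here, replacing 4-methylphenyl with 2-phenylethenyl on this saturated chain carbon gives a 1.1-fold lower number from compound 1 to compound 3 (0.03 log units; within the scatter) in this assay, the first step that can be read at this position. Adding a double bond outside the aromatic rings while keeping one aromatic ring of carbon only therefore produces no change that can be separated from the scatter, and compound 3 stays in the same weak range as compound 1. Nothing measured here accounts for this result.

As far as these compounds go, both groups carry an aromatic ring of carbon only and have no hydrogen-bond donors or acceptors, so it remains open whether an amine, a carboxylic acid or a plain alkyl chain at this position would move the number beyond the scatter. A saturated 2-phenylethyl group would show whether the double bond matters at all.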